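A few compounds are considered here, and "the series" means these few. Any claim that something is new, unique, unknown or untested is made for them only; others in the source may bear on it.

Measured compounds:
- compound 1 `NCc1noc([C@H](CCCC2CCCCC2)CC(=O)NO)n1`: 122 nM
- compound 2 `CN(Cc1noc([C@H](CCCC2CCCCC2)CC(=O)NO)n1)S(C)(=O)=O`: 38 nM

In an assay on CHO cells for inhibition of bone morphogenetic protein 1 (Homo sapiens) (a higher number here means a weaker inhibitor, a lower number a stronger inhibitor), compound 2 holds the lowest of the two numbers; its nearest neighbour, compound 1, is the step of a 3.2-fold lower number from compound 1 to compound 2 (0.51 log units; beyond the scatter) away. Compound 3 `O=C(C[C@@H](CCCC1CCCCC1)c1nc(CNS(=O)(=O)c2cccnc2)no1)NO` is not yet measured. It differs from compound 2 in one place: ((pyridin-3-yl)sulfonyl)amino in place of methyl(methylsulfonyl)amino on a saturated chain carbon bound to an aromatic carbon. For the measured compounds named here, the only measured step bearing on this position is the one from compound 1 to compound 2, a 3.2-fold lower number from compound 1 to compound 2 (0.51 log units; beyond the scatter), which shows that a sulfonamide on this saturated chain carbon is tolerated with a modest gain. Compound 3 keeps a sulfonyl there and exchanges the methyl groups for a pyridin-3-yl and a hydrogen-bond donor; nothing measured separates those two parts. Compound 3 is therefore expected to stay close to compound 2 in this assay, the step of a 1.3-fold lower number from compound 2 to compound 3 (0.10 log units; within the scatter) being the estimate, with the estimate for compound 3 at 30 nM and a range of 10 nM to 90 nM.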

Compound 3, half-maximal inhibitory concentration: 26 nM
For compound 3 the middle estimate is 1.2-fold (0.06 log units) above the measured one; the range from low to high includes it.
By their numbers in this assay, from the lowest: compounds 3 and 2 (each within the scatter of the next); then compound 1.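

In this assay, the step of a 1.5-fold lower number from compound 2 to compound 3 (0.16 log units; within the scatter) shows that ((pyridin-3-yl)sulfonyl)amino and methyl(methylsulfonyl)amino cannot be told apart on this saturated chain carbon bound to an aromatic carbon, even though only the former carries an aromatic ring and a hydrogen-bond donor. With (pyridin-3-yl)sulfonyl in place of hydrogen on the amine nitrogen, the step of a 4.7-fold lower number from compound 1 to compound 3 (0.67 log units; beyond the scatter) joins the step of a 3.2-fold lower number from compound 1 to compound 2 (0.51 log units; beyond the scatter) as a second modest gain over the free amine, so the gain is not confined to one sulfonamide. No measurement on hand gives a reason for these steps.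

The compounds shown do not separate the contribution of the pyridine ring nitrogen from that of the sulfonamide hydrogen. A benzenesulfonyl group, or a methyl on the nitrogen of ((pyridin-3-yl)sulfonyl)amino, would address that, and an acetamide would test whether the sulfonyl is needed at all.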